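The source may hold more compounds than are shown below. What is called first, only, known or untested is meant among the compounds shown, and "the series" means these compounds.

Working notes on the series.

Of the compounds shown here, three have been measured in an assay on HEK293 cells for agonist activity at transient receptor potential cation channel subfamily M member 8 (Homo sapiens), read by fluorescence and calcium flux, with a stated time of 15 min; on this read-out higher numbers stand for an effect only at larger amounts of compound and lower numbers for an effect already at smaller amounts. Compound 1 `Cc1ccc(OCC(=O)N(Cc2cccs2)CC(C)C)cc1` gives 900 nM. Compound 3 `Cc1ccc(OCC(=O)N(C)Cc2cccs2)cc1` gives 400 nM. Compound 2 `CCN(Cc1cncs1)C(=O)COc1ccc(C)cc1` gives 1100 nM. On these numbers compound 2 and compound 1 cannot be told apart, their gap lying within the scatter; compound 3 stands apart from compound 2 by a difference beyond the scatter, with the lower number on the side of compound 3.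

Going by the values given here, the one step between measured compounds that differ in one place is a 2.3-fold lower number from compound 1 to compound 3 (0.35 log units; beyond the scatter). It concerns the substituent on the saturated chain carbon bound to the amide-type nitrogen, not the aromatic ring carried on that carbon.

Compound 4 `CCN(Cc1nccs1)C(=O)COc1ccc(C)cc1` has not yet been measured. It differs from compound 2 by 1,3-thiazol-2-yl in place of 1,3-thiazol-5-yl on a saturated chain carbon bound to an amide-type nitrogen. Among the compounds with values here, no measured step in this assay touches the point of attachment of a thiazolyl ring; the available step speaks to another position and gives no direction for this one. Without a bearing step, the expectation for compound 4 in this assay is a change not beyond the scatter, which is what a 1.1-fold lower number from compound 2 to compound 4 (0.04 log units; within the scatter) expresses. Compound 4 is therefore estimated at 1000 nM, with a range from 400 nM to 2500 nM.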

Compound 4, half-maximal effective concentration: 3060 nM
For compound 4 the middle estimate is 3.1-fold (0.49 log units) below the measured one; the whole stated range lies below it.
By their numbers in this assay, from the lowest: compound 3; then compounds 1 and 2 (each within the scatter of the next); then compound 4.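

Moving the point of attachment of the thiazolyl ring, with no atom gained or lost, gives a 2.8-fold higher number from compound 2 to compound 4 (0.44 log units; beyond the scatter) in this assay, so the result at this position depends on how the ring is joined as well as on which atoms it holds. Going by these compounds alone, the earlier step spoke only to the substituent on the saturated chain carbon bound to the amide-type nitrogen, whereas this is the first step that touches the aromatic ring carried there, and it shows that the ring is not interchangeable between 1,3-thiazol-5-yl and 1,3-thiazol-2-yl, although the two groups match in heavy atoms, hydrogen-bond donors, hydrogen-bond acceptors and net charge. Nothing at hand accounts for the difference between the two attachment points.

On these data alone, it remains open where 1,3-thiazol-4-yl or a plain phenyl ring on the same chain carbon would fall relative to these two thiazolyl isomers. As far as these compounds go, it is also open whether the same change in attachment would carry the same size of step with a methyl group or a longer chain in place of the ethyl group on the amide-type nitrogen.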